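Working notes: from compound 1 to compound 4

A few compounds are considered here, and "the series" means these few. Any claim that something is new, unique, unknown or untested is made for them only; others in the source may bear on it.

compound 1 `O=C(O)c1ccc2nc(CN3CCC[C@H](O[C@H](CO)c4cc(Cl)cc(Cl)c4)[C@@H]3c3ccccc3)[nH]c2c1` — 380 nM
compound 2 `Cc1cc(C(=O)O)ccc1CN1CCC[C@H](O[C@H](CO)c2cc(Cl)cc(Cl)c2)[C@@H]1c1cccc(F)c1` — 12000 nM
compound 3 `Cc1cc(C(=O)O)ccc1CN1CCC[C@H](O[C@H](CS(C)(=O)=O)c2cc(Cl)cc(Cl)c2)[C@@H]1c1ccccc1` — 330 nM

Within the data shown here, in an assay on isolated protein for activation of cGMP-dependent protein kinase 1 (Homo sapiens), read by ADP-Glo, with stated times of 30 min and 2 h, in the presence of a further agent that is not named here (on this read-out lower numbers stand for an effect already at smaller amounts and higher numbers for an effect only at larger amounts of compound), compound 1 gives 380 nM, the second highest of the three numbers measured so far. Nearest to it stands compound 3 with 330 nM, a gap within the usual scatter, so no order between these two can be read. Furthest away is compound 2 with 12000 nM, a gap well beyond the scatter.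

Compound 4 `COC(=O)c1ccc(CN2CCC[C@H](O[C@H](CO)c3cc(Cl)cc(Cl)c3)[C@@H]2c2ccccc2)c(C)c1` has not yet been measured. It differs from compound 1 in one place: a group of 11 heavy atoms (9 carbon, 2 oxygen; one six-membered aromatic ring of carbon only) in place of a group of 12 heavy atoms (8 carbon, 2 nitrogen, 2 oxygen; one five-membered aromatic ring with 2 hetero atoms, one six-membered aromatic ring of carbon only), on a saturated chain carbon bound to an amine nitrogen in a ring. The group that leaves carries both hydrogen-bond donors of the exchanged part; the group that enters carries none. Among the measured compounds shown here, no pair of measured compounds isolates this change, and each of compounds 2 and 3 differs from compound 4 in more than one place, so their values give only a rough frame.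

The step is expected to go upward and to exceed the scatter, with an estimated step of a 7.9-fold higher number from compound 1 to compound 4 (0.90 log units; beyond the scatter). For the measured compounds named here, for compound 4 the estimate in this assay is 3000 nM, with a range from 600 nM to 15000 nM; the wide range reflects that no measured step covers this change.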

Compound 4, half-maximal effective concentration: 900 nM
Beside the measured number, compound 4's estimate is 3.3-fold (0.52 log units) above it; the measured number falls inside the stated range.
By their numbers in this assay, from the lowest: compounds 3 and 1 (each within the scatter of the next); then compound 4; then compound 2.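

In this assay, among these compounds, the exchange on a saturated chain carbon bound to an amine nitrogen in a ring gives the first readable step at this position: a 2.4-fold higher number from compound 1 to compound 4 (0.37 log units; beyond the scatter), beyond the scatter but modest. A group with 0 hydrogen-bond donors and only a six-membered aromatic ring of carbon thus replaces one with 2 hydrogen-bond donors and an additional five-membered aromatic ring with 2 hetero atoms, and on this core neither feature proves indispensable for an effect in this assay, though the exchange does carry a measurable cost. No measurement is available that bears on the origin of this shift.

The exchange alters the ring system and the hydrogen-bond donors together, and steps from compound 4 to compounds 2 and 3 cannot be read, as each differs from it in more than one place, so the share of each change in the step stays unresolved. Also open, on these data alone, is whether a carboxylic acid or a primary amide in place of the ester of compound 4, on an otherwise unchanged core, would recover or further shift the number.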